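From Isopropylamino to (2-Methoxyphenyl)amino: an Expectation

The compounds below may be only part of what the source reports. "The series", "measured", "known", "first", "only" and "open" are said of these compounds alone.

Compound 1 `Cc1cc(NC(C)C)nc(SCc2nc3ccccc3[nH]2)n1` is known in a functional assay on MGC-803 cells (Homo sapiens) for cytotoxicity, read by MTT assay, with a stated time of 72 h (a higher number here means a weaker inhibitor, a lower number a stronger inhibitor), only as a limit; in this assay compound 1 gives > 100000 nM. Compound 2 `Cc1cc(NNC(N)=S)nc(SCc2nc3ccccc3[nH]2)n1` likewise gives only a limit in this assay, > 100000 nM. Among the compounds with values here, the single measured step, a step that the two limits leave unreadable from compound 1 to compound 2, is unreadable, and the limit of > 100000 nM in this assay, at which 2 of the 2 values shown sit, is all the evidence at hand. Compound 3 `COc1ccccc1Nc1cc(C)nc(SCc2nc3ccccc3[nH]2)n1` differs from compound 1 by 2-methoxyphenyl in place of isopropyl on a nitrogen on an aromatic ring. Within the data shown here, no measured step bears on this change, so neither size nor direction can be read from the data. Compound 3 is nevertheless estimated at 50000 nM, between 10000 nM and 150000 nM. The step of an at least 2.0-fold lower number from compound 1 to compound 3 (0.30 log units; that floor lies within the scatter) is thus expected, not measured.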

Compound 3, half-maximal inhibitory concentration: 56200 nM
Estimate against measurement, compound 3: 1.1-fold (0.05 log units) below; low and high end bracket the measured number.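

On this nitrogen, 2-methoxyphenyl gives the one number shown in this assay rather than a limit of the assay: the limit of > 100000 nM in this assay, at which 2 of the 3 values shown sit.

The change gives an at least 1.7-fold lower number from compound 1 to compound 3 (0.25 log units; that floor lies within the scatter), and the comparison with the other group gives an at least 1.7-fold lower number from compound 2 to compound 3 (0.25 log units; that floor lies within the scatter). Both are floors, so neither the full size of these steps nor a real gain is established.

The compounds shown leave open whether the aromatic ring or the methoxy group carries this step. Plain phenylamino or a benzylamino group on the same nitrogen stands outside them.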